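A few compounds are considered here, and "the series" means these few. Any claim that something is new, unique, unknown or untested is made for them only; others in the source may bear on it.

Measured in a functional assay on LNCaP cells (Homo sapiens) for cytotoxicity, read by MTT assay, with a stated time of 72 h; a higher number here means a weaker inhibitor, a lower number a stronger inhibitor:
Compound 1 `Brc1cccc2cc3c(nc12)-c1nc2ccccc2n1C3` — 8400 nM
Compound 2 `Cc1ccc2cc3c(nc2c1)-c1nc2ccccc2n1C3` — 39000 nM
Compound 3 `Cc1ccc2nc3c(cc2c1)Cn1c-3nc2ccccc21` — 62500 nM

Compound 1 gives the lowest number of the three in this assay; the values of compound 2 and of compound 3 both stand higher than that of compound 1, each by more than the usual scatter, so compound 1 is the strongest inhibitor among the measured set. Compound 4 `COc1cccc2cc3c(nc12)-c1nc2ccccc2n1C3` has not been measured. It differs from compound 1 in one place: methoxy in place of bromo on an aromatic carbon. Among the measured compounds shown here, no measured pair shows this change, so its effect can only be guessed. A modest rise in the number is expected, since the other substituents on this ring gave weaker inhibitors than the bromo of compound 1. The step of a 2.1-fold higher number from compound 1 to compound 4 (0.33 log units; beyond the scatter) is estimated to go upward beyond the scatter. Compound 4 is expected at 18000 nM, within 5000 nM to 60000 nM.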

Compound 4, half-maximal inhibitory concentration: 20000 nM
Compound 4: middle estimate off by 1.1-fold (0.05 log units), on the low side; the measured number falls inside the stated range.
By their numbers in this assay, from the lowest: compound 1; then compounds 4, 2 and 3 (each within the scatter of the next, the first and the last beyond it).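

In this assay, among the compounds shown here, this pair gives the first direct reading of a single change at this position: methoxy in place of bromo, on an aromatic carbon ortho to a fused ring, brings a 2.4-fold higher number from compound 1 to compound 4 (0.38 log units; beyond the scatter) in a modest step. The number at this position therefore responds to the substituent, and of these two groups bromo gives the lower number. Nothing measured here accounts for the step. From the compounds shown here alone, whether an amine, a carboxylic acid or a longer alkoxy chain at this position would lower or raise the number remains open, as does the effect of the unsubstituted carbon.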